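Amide nitrogen substituents on a chromone acrylamide core

The source may report more compounds than this note shows. Statements on the series, on what has been measured and on what is new or still open speak of the compounds shown alone.

Measured so far:
Compound 1 `COc1ccc2c(=O)c(/C=C/C(=O)NCc3ccccc3)coc2c1` — in a functional assay (QGY7701 cells, Homo sapiens) for inhibition, read by MTT assay, with a stated time of 48 h (a lower number here means a stronger inhibitor, a higher number a weaker inhibitor), compound 1 gives > 100000 nM, which is a limit of the assay and not a number.
Compound 2 `COc1ccc2c(=O)c(/C=C/C(=O)Nc3ccccc3OC)coc2c1` — in this assay compound 2 gives 17600 nM.

Among the compounds with values here, compound 2 holds the only actual number in this assay; the other value shown is a limit. Within the data shown here, the one measured step, an at least 5.6-fold lower number from compound 1 to compound 2 (0.75 log units; beyond the scatter), runs from the benzyl amide to the 2-methoxyphenyl amide and is bounded on one side by the limit of > 100000 nM in this assay, at which 1 of the 2 values shown sits.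

Compound 3 `COc1ccc2c(=O)c(/C=C/C(=O)Nc3ccc(C)cc3)coc2c1` is not yet measured. It differs from compound 2 by 4-methylphenyl in place of 2-methoxyphenyl on an amide-type nitrogen. No measured step covers an exchange of one aryl substituent for another on the amide nitrogen; the single step shown concerns the change from benzyl to aryl, and compound 3 keeps an aryl group on that nitrogen. The step from compound 2 to compound 3 is therefore expected to be small, a 1.4-fold higher number from compound 2 to compound 3 (0.15 log units; within the scatter), with the estimate leaning toward a somewhat higher number given how little of the series is known. For compound 3 the estimate in this assay is 25000 nM, ranging from 8000 nM to 90000 nM.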

Compound 3, half-maximal inhibitory concentration: 39300 nM
For compound 3 the middle estimate is 1.6-fold (0.20 log units) below the measured one, and the stated range covers the measured number.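

In this assay, swapping one aryl group for another on the amide nitrogen is not a silent change: the exchange gives a 2.2-fold higher number from compound 2 to compound 3 (0.35 log units; beyond the scatter), so the read-out depends on which aryl group is present, and not only on whether the nitrogen carries an aryl group rather than benzyl. The lower number seen on going from benzyl to 2-methoxyphenyl now has a second example with a different aryl group, with an at least 2.5-fold lower number from compound 1 to compound 3 (0.40 log units; beyond the scatter) on going from benzyl to 4-methylphenyl, although two aryl amides are a small basis and both remain weak in absolute terms. The value of compound 1 is a limit and not a number, so both steps from it are bounded on one side only: the limit of > 100000 nM in this assay, at which 1 of the 3 values shown sits.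

The step from 2-methoxyphenyl to 4-methylphenyl changes both the substituent and its place on the ring, and the compounds shown do not separate these two changes. Also open, as far as these compounds go, is how a plain phenyl or an aminophenyl group on the amide nitrogen would compare with compound 2, which gives 17600 nM in this assay.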